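From 2-methylphenyl to 3-methoxyphenyl in a narrow series

The compounds below may be only part of what the source reports. "The series", "measured", "known", "first", "only" and "open" are said of these compounds alone.

compound 1 `CC1(C)[C@H]2CC[C@]1(C)N(Cc1cn(-c3ccccc3C#N)nn1)C(=O)C2` gives 180 nM
compound 2 `COc1ccccc1-n1cc(CN2C(=O)C[C@@H]3CC[C@@]2(C)C3(C)C)nn1` gives 110 nM
compound 3 `Cc1ccccc1-n1cc(CN2C(=O)C[C@@H]3CC[C@@]2(C)C3(C)C)nn1` gives 150 nM

In a functional assay on HepG2 cells (Homo sapiens) for inhibition, read by MTT assay, with a stated time of 24 h (a lower number here means a stronger inhibitor, a higher number a weaker inhibitor), the three measured compounds lie within the scatter of one another, and compound 3 at 150 nM is not separated from either of the others. Compound 4 `COc1cccc(-n2cc(CN3C(=O)C[C@@H]4CC[C@@]3(C)C4(C)C)nn2)c1` has not yet been measured. Its difference from compound 3 is 3-methoxyphenyl in place of 2-methylphenyl on an aromatic nitrogen with 3-methoxyphenyl in place of 2-methylphenyl on an aromatic nitrogen.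

Going by the values given here, three measured steps bear on this change, since each exchanges one group on the aromatic ring. They are a 1.4-fold higher number from compound 2 to compound 3 (0.13 log units; within the scatter) and a 1.2-fold lower number from compound 1 to compound 3 (0.08 log units; within the scatter) and also a 1.6-fold lower number from compound 1 to compound 2 (0.21 log units; within the scatter) and all of them stay within the scatter. Methyl, methoxy and cyano have so far left the number in this assay without a step beyond the scatter. Among the compounds with values here, none of the measured compounds carries the 3-methoxyphenyl group, however, so the data do not show what this placement does, and the range is kept wider than the measured spread. No change beyond the scatter is expected, and the estimated step is a 1.1-fold lower number from compound 3 to compound 4 (0.03 log units; within the scatter) in this assay overall. Compound 4 is expected at 140 nM with an estimated range of 60 nM to 350 nM in this assay.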

Compound 4, half-maximal inhibitory concentration: 70 nM
Beside the measured number, compound 4's estimate is 2.0-fold (0.30 log units) above it; the range from low to high includes it.
By their numbers in this assay, from the lowest: compounds 4, 2, 3 and 1 (each within the scatter of the next, the first and the last beyond it).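

In this assay, the aryl group on the aromatic nitrogen now gives steps beyond the scatter, which none of the earlier exchanges of methyl, methoxy and cyano had done: a 2.1-fold lower number from compound 3 to compound 4 (0.33 log units; beyond the scatter), and a 2.6-fold lower number from compound 1 to compound 4 (0.41 log units; beyond the scatter). The same comparison does not separate the two methoxy placements, as the change from 2-methoxyphenyl to 3-methoxyphenyl gives a 1.6-fold lower number from compound 2 to compound 4 (0.20 log units; within the scatter), so the compounds support a difference from the 2-methylphenyl and 2-cyanophenyl compounds but not a distinct effect of moving the methoxy group. Nothing measured here explains these steps, and no supporting evidence bears on them.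

On these data alone, what remains open is whether the methoxy group itself matters at this placement, a question that a plain phenyl group on the aromatic nitrogen would help to answer. It is also open how far this position tolerates larger or charged replacements, such as an amine or a carboxylic acid in place of the methoxy group of the 3-methoxyphenyl ring, since the compounds shown span only a narrow set of groups.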